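Methanesulfonamido for hydroxymethyl on the biaryl core

A few compounds are considered here, and "the series" means these few. Any claim that something is new, unique, unknown or untested is made for them only; others in the source may bear on it.

Going by the values given here, compound 1 `OCc1ccc(-c2ccc3c(O)cccc3c2)cc1` is the only member of the series that returns a number in an assay for binding affinity to 17-beta-hydroxysteroid dehydrogenase type 1 (Homo sapiens), with a stated time of 20 min, tested at 1 uM (on this read-out higher numbers stand for more inhibition at the one concentration tested (going by the name of the read-out) and lower numbers for less inhibition), where compound 1 gives 14%. In this assay compound 2 `COc1ccncc1-c1ccc2c(O)cccc2c1` returns only a limit, < 10%, and not a number. The series thus sits close to the floor of the read-out, as shown by the limit of < 10% in this assay, at which 1 of the 2 values shown sits, and no step between two measured compounds is available to calibrate the change now considered.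

Compound 3 `CS(=O)(=O)Nc1ccc(-c2ccc3c(O)cccc3c2)cc1` differs from compound 1 in one place: methanesulfonamido in place of hydroxymethyl on an aromatic carbon. Compound 1 at 14% leaves little room for a fall beyond the scatter. Without a measured step to lean on, the step of a number 6 percentage points higher from compound 1 to compound 3 (within the scatter) is expected to be small, within the scatter, with direction uncertain. The estimate for compound 3 in this assay is 20%, in a range from 5% to 45%, with a real chance that only a limit is reported.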

Compound 3, a percentage reported as inhibition, at one concentration (the size of the read-out at that concentration, not a potency): 52%
For compound 3 the middle estimate is 32 percentage points below the measured one, and the stated range ends below it.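

At this position, an aromatic carbon para to a large group, this assay responds clearly to the substituent: methanesulfonamido in place of hydroxymethyl gives a number 38 percentage points higher from compound 1 to compound 3 (beyond the scatter). Going by these compounds alone, this is the first measured step, and it shows that one change at this position can move the read-out beyond the scatter. The series is also no longer confined to the floor of the read-out: the limit of < 10% in this assay, at which 1 of the 3 values shown sits.

This single step cannot separate the contributions of the sulfonyl part, the nitrogen link and the larger size of the entering group. From the compounds shown here alone, it remains open whether an amine, a carboxylic acid or a longer chain on the sulfonamide would hold this level at the same position, and the single-concentration read-out gives no potency for compound 3.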